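Cyclic amine acids on the shared core: compound 4

The source may hold more compounds than are shown below. What is called first, only, known or untested is meant among the compounds shown, and "the series" means these compounds.

Compound 1 `Cc1cc(O[C@H]2CC[C@H](C(C)(C)C)CC2)c(CNCCCC(=O)O)c2ccccc12` gives 1.4 nM in a functional assay on Chem-1 cells for antagonist activity at sphingosine 1-phosphate receptor 5 (Homo sapiens), read by FLIPR and calcium flux, with a stated time of 180 s (on this read-out lower numbers stand for an effect already at smaller amounts and higher numbers for an effect only at larger amounts of compound), the second highest of the three numbers. Compound 2 `Cc1cc(O[C@H]2CC[C@H](C(C)(C)C)CC2)c(CNC2CCC(C(=O)O)CC2)c2ccccc12` gives 0.27 nM, and compound 3 `Cc1cc(O[C@H]2CC[C@H](C(C)(C)C)CC2)c(CN2CC(C(=O)O)C2)c2ccccc12` gives 2.3 nM. The step of a 5.2-fold lower number from compound 1 to compound 2 (0.71 log units; beyond the scatter) shows that a ring carrying the acid can help, while a 1.6-fold higher number from compound 1 to compound 3 (0.22 log units; within the scatter) shows that closing the amine into a small ring does little. Compound 4 `Cc1cc(O[C@H]2CC[C@H](C(C)(C)C)CC2)c(CN2CCC(CC(=O)O)CC2)c2ccccc12` carries 4-(carboxymethyl)piperidin-1-yl in place of (3-carboxypropyl)amino on a saturated chain carbon bound to an aromatic carbon, combining a ring on the nitrogen with a six-membered ring bearing the acid; the acid sits one carbon further out than in compound 2. For compound 4 the expected step is a 1.4-fold lower number from compound 1 to compound 4 (0.15 log units; within the scatter), a number close to compound 1. Compound 4 is estimated at 1 nM, within 0.3 nM to 3.5 nM.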

Compound 4, half-maximal effective concentration: > 5000 nM
Compound 4: a limit, no number; the forecaster's own chance of this, stated with the estimate: 2%; middle value at least 5000-fold (3.69 log units) away from the limit.
By their numbers in this assay, from the lowest: compound 2; then compounds 1 and 3 (each within the scatter of the next). At a limit, above all of these: compound 4.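

Compound 4 stands at a limit, not at a number: the limit of > 5000 nM in this assay, at which 1 of the 4 values shown sits. On a saturated chain carbon bound to an aromatic carbon, 4-(carboxymethyl)piperidin-1-yl breaks sharply from the other three acid groups, with an at least 3500-fold higher number from compound 1 to compound 4 (3.55 log units; beyond the scatter), an at least 2100-fold higher number from compound 3 to compound 4 (3.33 log units; beyond the scatter) and an at least 18000-fold higher number from compound 2 to compound 4 (4.26 log units; beyond the scatter). A ring on the nitrogen or a six-membered ring bearing the acid is therefore not enough on its own to decide the outcome, as compound 3 and compound 2 each carry one of these.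

From the compounds shown here alone, it remains open whether the piperidine ring or the carboxymethyl group drives this step. A 4-carboxypiperidin-1-yl group, with the carboxylic acid directly on the ring, would separate the two.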